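Chloro to methyl on compound 1: working notes

The source may hold more compounds than are shown below. What is called first, only, known or untested is meant among the compounds shown, and "the series" means these compounds.

Compound 1 (`CNC(=O)c1cc(C(=O)N[C@H]2CC[C@H](O)CC2)n([C@@H](C)c2cccc(Cl)c2)n1`) has no exact reading in a physicochemical assay for solubility, measured as kinetic solubility (on this read-out higher numbers stand for higher solubility and lower numbers for lower solubility), so far. Compound 1 gives >= 143 ug/mL as a limit of the assay and not as a number. Compound 2 (`CNC(=O)c1cc(C(=O)N[C@H]2[C@@H]3C[C@H](O)C[C@@H]32)n([C@@H](C)c2cccc(Cl)c2)n1`) gives >= 168 ug/mL and this too is a limit. Compound 3 (`CNC(=O)c1cc(C(=O)N[C@H]2CC[C@H](O)CC2)c([C@@H](C)c2cccc(OC)c2)o1`) gives >= 113 ug/mL and this is likewise a limit. No exact reading therefore stands anywhere among the measured compounds, so compound 1 cannot be ranked against the other two.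

Compound 4 (`CNC(=O)c1cc(C(=O)N[C@H]2CC[C@H](O)CC2)n([C@@H](C)c2cccc(C)c2)n1`) carries methyl in place of chloro on an aromatic carbon meta to a large group, and the rest of compound 1 stays as it is.

Within the data shown here, only one measured step is available, a step that the two limits leave unreadable from compound 1 to compound 2 on the amide-type nitrogen. It lies elsewhere in the molecule and offers no size to carry over. Among the measured compounds shown here, no measured step replaces chloro. The expectation therefore rests on the limit of compound 1 at >= 143 ug/mL and on the small size of the swap.

The estimated step is a step that the limit leaves unreadable from compound 1 to compound 4 in this assay and it is expected to stay within the usual scatter, with no direction favoured. Compound 4 is expected at 150 ug/mL with an estimated range from 95 ug/mL to 195 ug/mL. Compound 4 may well yield only a limit too.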

Compound 4, solubility: >= 180 ug/mL
Compound 4: no number, only a limit; the forecaster's own chance of this, stated with the estimate: 75%; middle value at least 1.2-fold (0.07 log units) from the limit.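

In this assay compound 4 gives >= 180 ug/mL, and this is a limit of the assay and not a number. Compound 1 also stands only as a limit, so no step can be read between compound 1 and compound 4. The compounds shown leave open whether methyl and chloro differ at all in this assay: none of the four has an exact reading.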